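Ethoxy for Methoxy at the Cytotoxicity Ceiling

The source may report more compounds than this note shows. Statements on the series, on what has been measured and on what is new or still open speak of the compounds shown alone.

Measured so far:
compound 1 `CCOC(=O)CCCCCOc1cccc(CN(C(=O)c2ccc(-c3ccc4ccccc4c3)cc2)C(C)C)c1` gives > 26000 nM in an ADME assay on BJ cells (Homo sapiens) for cytotoxicity, read by CellTiter-Glo and resazurin assay, with a stated time of 72 h; on this read-out lower numbers stand for an effect already at smaller amounts and higher numbers for an effect only at larger amounts of compound
compound 2 `CCOC(=O)CCCCCOc1cccc(CN(C(=O)c2ccc(-c3ccoc3)cc2)C(C)C)c1` gives > 26000 nM in this assay
compound 3 `CCOC(=O)CCCCCOc1cccc(CN(C(=O)c2ccc(-c3cccc(OC)c3)cc2)C(C)C)c1` gives > 21000 nM in this assay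

Each of these three values is a limit of this assay, not a number. For compound 3 the value > 21000 nM is such a limit. Compound 1 sits at another limit, > 26000 nM, and so does compound 2 with > 26000 nM. Because all three sit at limits, the steps a step that the two limits leave unreadable from compound 1 to compound 3 and a step that the two limits leave unreadable from compound 2 to compound 3, as well as a step that the two limits leave unreadable from compound 1 to compound 2, cannot be read in size or direction; what they show is summed up by the limit of > 21000 nM in this assay, at which 1 of the 3 values shown sits, and (the limit of > 26000 nM in this assay, at which 2 of the 3 values shown sit).

Compound 4 `CCOC(=O)CCCCCOc1cccc(CN(C(=O)c2ccc(-c3cccc(OCC)c3)cc2)C(C)C)c1` differs from compound 3 by methyl in place of hydrogen on a saturated chain carbon bound to an oxygen on an aromatic ring. For the measured compounds named here, no measured step bears on this change with a readable size. Compound 3 already sits at a limit, so for compound 4 no step beyond the scatter is expected in this assay, and the step that the limit leaves unreadable from compound 3 to compound 4 is expected to be small. Compound 4 is estimated at 30000 nM, between 15000 nM and 80000 nM, most likely reported again as a limit.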

Compound 4, half-maximal effective concentration: > 22300 nM
Compound 4: no number, only a limit; the forecaster's own chance of this, stated with the estimate: 85%; the middle value lies beyond the limit too.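

Compound 4 gives only a limit in this assay, not a number, and the steps to it from compound 1, compound 2 and compound 3 cannot be read in size or direction. The compounds shown leave open at what concentration any of these four reaches its half-maximal effect on these cells.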